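Tetrazole in place of ester: expected permeability of compound 3

A few compounds are considered here, and "the series" means these few. Any claim that something is new, unique, unknown or untested is made for them only; others in the source may bear on it.

Compound 1 `O=C(O)c1cc(Cl)cc2cc(CNC(=O)c3cnn4cccnc34)oc12`: 31 nm/s in an ADME assay for permeability, using PAMPA, at pH 5.5; on this read-out lower numbers stand for lower permeability and higher numbers for higher permeability
Compound 2 `C[C@@H](OC(=O)c1cc(Cl)cc2cc(CNC(=O)c3cnn4cccnc34)oc12)C(F)(F)F`: "not determined" (no result reported) in this assay

Compound 2 stands on no number of its own here. The next compound, compound 3 `O=C(NCc1cc2cc(Cl)cc(-c3nn[nH]n3)c2o1)c1cnn2cccnc12`, carries one change against compound 2: 2H-tetrazol-5-yl in place of (1-(trifluoromethyl)ethoxy)carbonyl on an aromatic carbon. Within the data shown here, with no measured step of this kind, the size of the step from compound 2 to compound 3 in this assay cannot be read from a neighbouring pair. Among the measured compounds shown here, compound 1, the only compound with a number, sets the scale for this series. Compound 3 is expected to read near compound 1, at about 25 nm/s, within 8 nm/s to 80 nm/s.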

Compound 3, apparent permeability: 144 nm/s
The estimate for compound 3 lay 5.8-fold (0.76 log units) below the measured number; the whole stated range lies below it.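

In this assay, 2H-tetrazol-5-yl in place of carboxy on this aromatic carbon gives a 4.6-fold higher number from compound 1 to compound 3 (0.67 log units; beyond the scatter). This shows that the read-out responds to the group at this position, and that a replacement for carboxy can raise the number on the shared core. The step from compound 2 to compound 3 cannot be read, and nothing at hand explains the rise.

Still open, from the compounds shown here alone, is how a primary amide or a nitrile on this aromatic carbon would read. Also open, going by these compounds, is whether the step would hold with a fluoro group in place of the chloro group.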